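Removing a Methyl Group: Expected Cytotoxicity of Compound 3

A few compounds are considered here, and "the series" means these few. Any claim that something is new, unique, unknown or untested is made for them only; others in the source may bear on it.

Measured so far:
Compound 1 `CNc1nc(Nc2ccc(C#N)cc2)nc(Oc2ccc3cc(Br)ccc3c2)n1`: 194000 nM
Compound 2 `CNc1nc(Nc2ccc(C#N)cc2)nc(Oc2ccc3cc(Br)ccc3c2Br)n1`: 92800 nM

In an ADME assay on MT4 cells (Homo sapiens) for cytotoxicity, read by MTT assay, with a stated time of 4 days (a higher number here means that more compound is tolerated, a lower number that less compound is tolerated), compound 1 gives 194000 nM, the higher of the two numbers measured. Within the data shown here, the only measured step, a 2.1-fold lower number from compound 1 to compound 2 (0.32 log units; beyond the scatter), concerns a bromo added to an aromatic carbon and says nothing about the nitrogen changed here. Compound 3 `N#Cc1ccc(Nc2nc(N)nc(Oc3ccc4cc(Br)ccc4c3)n2)cc1` differs from compound 1 by hydrogen in place of methyl on a nitrogen on an aromatic ring. Among the measured compounds shown here, with no measured step bearing on this change, no step beyond the scatter is expected for compound 3 in this assay, no change at the digits printed from compound 1 to compound 3 (within the scatter). Compound 3 is therefore estimated at 194000 nM, within a range of 97000 nM to 388000 nM.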

Compound 3, half-maximal cytotoxic concentration: 243000 nM
The estimate for compound 3 lay 1.3-fold (0.10 log units) below the measured number; measured number inside the range.
By their numbers in this assay, from the lowest: compound 2; then compounds 1 and 3 (each within the scatter of the next).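

Going from methylamino to amino gives a 1.3-fold higher number from compound 1 to compound 3 (0.10 log units; within the scatter) in this assay and is the only step shown at this nitrogen. On this evidence, the methyl group can be replaced by hydrogen here without a difference beyond the scatter, whereas the earlier step concerned a bromo on an aromatic carbon. No measurement at hand gives a reason for this result.

From the compounds shown here alone, whether a longer chain such as propyl or a ring such as cyclopropyl on this nitrogen would read the same remains open. Among these compounds, also open is whether adding the bromo to compound 3 would give a step like the one seen from compound 1 to compound 2.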